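Moving a methoxy group on the ring attached to the core nitrogen

The source may hold more compounds than are shown below. What is called first, only, known or untested is meant among the compounds shown, and "the series" means these compounds.

Three compounds sharing one core have been examined in a functional assay on PC-12 cells (Rattus norvegicus) for cytotoxicity, read by MTT assay, with stated times of 2 h and 24 h, tested at 1 uM; on this read-out lower numbers stand for a weaker effect and higher numbers for a stronger effect at the one concentration tested. Compound 1 `Cc1ccc(-n2nc(-c3ccc(C(F)(F)F)cc3O)nc2-c2ccccc2O)cc1` gives 71.5% in this assay; compound 2 `CCc1ccc(-n2nc(-c3ccc(C(F)(F)F)cc3O)nc2-c2ccccc2O)cc1` gives 64.4%; compound 3 `COc1ccc(-n2nc(-c3ccc(C(F)(F)F)cc3O)nc2-c2ccccc2O)cc1` gives 69%. Compound 1 holds the highest of the three numbers, but its distances to the others are small: a number 2.5 percentage points lower from compound 1 to compound 3 (within the scatter) and a number 7.1 percentage points lower from compound 1 to compound 2 (within the scatter), so the three values sit within the scatter of one another and no order among them can be claimed.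

Compound 4 `COc1ccccc1-n1nc(-c2ccc(C(F)(F)F)cc2O)nc1-c1ccccc1O` has not yet been measured. It differs from compound 1 by 2-methoxyphenyl in place of 4-methylphenyl on an aromatic nitrogen. Within the data shown here, the nearest measured step is the one from compound 1 to compound 3, where a methoxy replaced a methyl on an aromatic carbon and produced only a number 2.5 percentage points lower from compound 1 to compound 3 (within the scatter); the step of a number 4.6 percentage points higher from compound 2 to compound 3 (within the scatter) likewise stayed within the scatter. Among the measured compounds shown here, none of the measured steps, however, moves a group to a different position on that ring, so this part of the change has no precedent among the three compounds. On the evidence that exists, he expects no step beyond the scatter, that is a number 3.5 percentage points lower from compound 1 to compound 4 (within the scatter). Accordingly compound 4 is estimated at 68%, within a range from 55% to 80%.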

Compound 4, a percentage reported as activity, at one concentration (the size of the read-out at that concentration, not a potency): 70.7%
Compound 4: the middle estimate sits 2.7 percentage points below what was measured, and the stated range covers the measured number.
By their numbers in this assay, from the lowest: compounds 2, 3, 4 and 1 (each within the scatter of the next).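

In this assay, 2-methoxyphenyl in place of 4-methoxyphenyl on the aromatic nitrogen gives a number 1.7 percentage points higher from compound 3 to compound 4 (within the scatter), and this is the only step shown that moves a group to a different position on that ring. Set against the two other groups on that nitrogen, the same 2-methoxyphenyl gives a number 0.8 percentage points lower from compound 1 to compound 4 (within the scatter) where 4-methylphenyl leaves and a number 6.3 percentage points higher from compound 2 to compound 4 (within the scatter) where 4-ethylphenyl leaves, so no pair among the four compounds can be put in an order. The ring on the aromatic nitrogen has thus carried methyl, ethyl and methoxy, the last at two positions, with no step beyond the scatter, and nothing measured offers an explanation for these results.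

The compounds shown leave open whether a different kind of group on this ring, such as an amine, a carboxylic acid or a longer chain, would produce a step beyond the scatter. They also leave open whether these four compounds would stay this close at other concentrations, as the values at one concentration give the size of the read-out and not a potency.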